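Anilinopyrimidine sulfonamides: swapping the five-membered ring on the core

The source may report more compounds than this note shows. Statements on the series, on what has been measured and on what is new or still open speak of the compounds shown alone.

Measured so far:
compound 1 `CCOC1=NN(c2nc(Nc3ccc(S(N)(=O)=O)cc3)nc(-c3ccc(OC)c(OC)c3)c2C#N)C(=O)C1`, 42 nM
compound 2 `COc1ccc(C2=C(C#N)C3=NCC(=O)N3C(Nc3ccc(S(N)(=O)=O)cc3)=N2)cc1OC`, 42 nM

In a functional assay on HeLa cells (Homo sapiens) for inhibition, read by sulforhodamine B assay, with a stated time of 48 h (on this read-out lower numbers stand for stronger inhibition and higher numbers for weaker inhibition), compound 1 gives 42 nM. Compound 2 gives 42 nM in this assay, and the two values stand level at the digits shown, within the scatter, so no order between them can be read from these numbers. Among the measured compounds shown here, no step between measured compounds that differ in one place is available, so the series offers no measured guide to how this kind of exchange moves the read-out.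

Compound 3 `COc1ccc(-c2nc(Nc3ccc(S(N)(=O)=O)cc3)nc(-n3nc(C)cc3C)c2C#N)cc1OC` is the next candidate. It differs from compound 1 in a group of 7 heavy atoms (5 carbon, 2 nitrogen; one five-membered aromatic ring with 2 hetero atoms) in place of a group of 9 heavy atoms (5 carbon, 2 nitrogen, 2 oxygen; one five-membered non-aromatic ring with 2 hetero atoms), on an aromatic carbon: the 3,5-dimethyl-1H-pyrazol-1-yl enters where the ethoxy-bearing non-aromatic ring leaves, next to the ring nitrogen and ortho to the cyano group.

For the measured compounds named here, with no measured step of this sort, only a modest move is expected; the step from compound 1 to compound 3 is estimated at a 1.9-fold higher number from compound 1 to compound 3 (0.28 log units; within the scatter), toward weaker inhibition, not far beyond the scatter. Compound 3 is expected to give about 80 nM in this assay, with a range of 25 nM to 250 nM.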

Compound 3, half-maximal inhibitory concentration: 41 nM
Compound 3: the middle estimate sits 2.0-fold (0.29 log units) above what was measured; low and high end bracket the measured number.
By their numbers in this assay, from the lowest: compounds 3, 1 and 2 (each within the scatter of the next).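

In this assay, placing 3,5-dimethyl-1H-pyrazol-1-yl on the aromatic carbon ortho to a cyano group, in place of the ethoxy-bearing non-aromatic ring, gives a 1.0-fold lower number from compound 1 to compound 3 (0.01 log units; within the scatter). Among the compounds shown here, this is the first measured step at this position, and it shows that the read-out does not separate a five-membered aromatic ring of 7 heavy atoms from a five-membered non-aromatic ring of 9 heavy atoms, even though the entering group carries no oxygen and no double bonds outside aromatic rings. No measurement on hand bears on why the two compounds stand level.

As far as these compounds go, a single step within the scatter cannot show whether this position accepts groups generally or whether these two groups merely happen to match, and the share of the two methyl groups in the value of compound 3 also stays unknown. An unsubstituted pyrazol-1-yl would address the methyl groups, while a morpholine ring, a primary amine or a carboxylic acid on the same carbon would test how far the level holds once the five-membered ring is gone.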